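The source may hold more compounds than are shown below. What is called first, only, known or untested is meant among the compounds shown, and "the series" means these compounds.

Compound 2 `COCCNC(=O)c1cc2c(C)cc(C)cc2[nH]1` carries a 2-methoxyethyl group on an amide-type nitrogen. Among the measured compounds shown here, in a physicochemical assay for solubility, measured as thermodynamic solubility, with a stated time of 24 h, at pH 6.8 (on this read-out higher numbers stand for higher solubility and lower numbers for lower solubility), compound 2 gives 620000 nM, the only plain number among the values shown. Compound 1 `Cc1cc(C)c2cc(C(=O)NC3CCCCCC3)[nH]c2c1` differs from compound 2 by carrying cycloheptyl in that place. In this assay compound 1 gives < 4000 nM, which is a limit of the assay and not a number. The step of an at least 150-fold higher number from compound 1 to compound 2 (2.19 log units; beyond the scatter) thus rests on (the limit of < 4000 nM in this assay, at which 1 of the 2 values shown sits). Compound 3 `Cc1cc(C)c2cc(C(=O)NC3CCCCC3O)[nH]c2c1` is not yet measured; it differs from compound 2 by 2-hydroxycyclohexyl in place of 2-methoxyethyl on an amide-type nitrogen. For the measured compounds named here, the one measured step, from the cycloheptyl of compound 1 to the 2-methoxyethyl of compound 2, was large and upward; the change now in view goes back toward a ring, though one bearing a hydroxyl. A lower number is therefore expected for compound 3, a step of a 16-fold lower number from compound 2 to compound 3 (1.19 log units; beyond the scatter) in this assay. Compound 3 is estimated at 40000 nM, in a range from 5000 nM to 300000 nM.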

Compound 3, solubility: 56000 nM
The estimate for compound 3 lay 1.4-fold (0.15 log units) below the measured number; measured number inside the range.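

Compound 3 shows that a ring on the amide-type nitrogen does not by itself bring the number down to the limit seen for compound 1. In this assay, the value stands between the two earlier ones, with an 11-fold lower number from compound 2 to compound 3 (1.04 log units; beyond the scatter) and an at least 14-fold higher number from compound 1 to compound 3 (1.14 log units; beyond the scatter). The second step starts from compound 1, whose value is a limit of the assay and not a number, so it has a floor but no exact size: the limit of < 4000 nM in this assay, at which 1 of the 3 values shown sits.

Cycloheptyl and 2-hydroxycyclohexyl differ in both ring size and the hydroxyl, so these compounds cannot show which of the two changes accounts for the higher number of compound 3. Going by these compounds, how plain cyclohexyl, an amine, a carboxylic acid or a longer chain would read in this place also stays open.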